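The source may report more compounds than this note shows. Statements on the series, on what has been measured and on what is new or still open speak of the compounds shown alone.

Of the compounds shown here, three have been measured so far in an assay on Cerebral cortex (strain Sprague-Dawley) for displacement of a labelled ligand from Neuronal acetylcholine receptor; alpha4/beta2 (Rattus norvegicus); on this read-out lower numbers stand for stronger inhibition and higher numbers for weaker inhibition. Compound 1 `CN1CCC[C@H]1[C@H]1COc2ccc(CO)cc2O1` gives 9500 nM. Compound 2 `CN1CCC[C@@H]1[C@@H]1COc2ccc(O)cc2O1` gives 3000 nM. Compound 3 `CN1CCC[C@H]1[C@H]1COc2ccc(O)cc2O1` gives 421 nM, the lowest of the three numbers, and its separation from each of the others lies beyond the scatter. Two steps lead to it. The first, a 23-fold lower number from compound 1 to compound 3 (1.35 log units; beyond the scatter), is large and changes a substituent on the aromatic ring. The second, a 7.1-fold lower number from compound 2 to compound 3 (0.85 log units; beyond the scatter), is modest and is tied to the fact that compounds 2 and 3 differ only in the configuration as drawn: the two compounds are mirror images of one another.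

Compound 4 `Oc1ccc2c(c1)O[C@@H]([C@@H]1CCCN1)CO2` is not yet measured. It differs from compound 3 by hydrogen in place of methyl on an amine nitrogen in a ring. Neither measured step speaks to this change: one alters the aromatic ring and the other inverts both stereocentres, while the ring nitrogen and its methyl are untouched in all three measured compounds. The expectation for compound 4 therefore rests on the rest of the structure being identical to that of compound 3, and the step of a 1.7-fold higher number from compound 3 to compound 4 (0.22 log units; within the scatter) is expected to be small, most likely toward a somewhat higher number but possibly within the scatter. Compound 4 is thus estimated to give 700 nM, with a range from 150 nM to 3000 nM.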

Compound 4, inhibition constant: 1200 nM
The estimate for compound 4 lay 1.7-fold (0.23 log units) below the measured number; the measured number falls inside the stated range.
By their numbers in this assay, from the lowest: compound 3; then compound 4; then compound 2; then compound 1.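

In this assay, the methyl on the amine nitrogen in the ring contributes to the result, since putting hydrogen in its place gives a 2.9-fold higher number from compound 3 to compound 4 (0.45 log units; beyond the scatter) and this modest step lies beyond the scatter. Within the data shown here, this is the first information about this position, because compounds 1, 2 and 3 all carry the same methyl there and their comparisons could only speak to the aromatic substituent and the configuration; here the loss of a single carbon atom is enough to move the number, so the nitrogen of the five-membered ring is a place where a small change can be read. Nothing in the available evidence accounts for the direction or size of this step.

The compounds shown leave open what a group larger than methyl on this nitrogen, such as ethyl, a longer chain like propyl or a benzyl group, would do to the number. On these data alone, it is also open whether the hydrogen-for-methyl step would keep its direction and size in the mirror-image configuration of compound 2 or with the hydroxymethyl group of compound 1.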